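Cyanophenyl for pyridyl on a tert-butyl-bearing core

The compounds below may be only part of what the source reports. "The series", "measured", "known", "first", "only" and "open" are said of these compounds alone.

Among the measured compounds shown here, compound 3 `COc1nc(-c2ccncc2)ccc1[C@@H](c1ccccc1)[C@@](O)(CCN(C)C)c1cccc2ccccc12` is the one member of this small set with a single number in a toxicity assay on HeLa cells (Homo sapiens) for cytotoxicity; on this read-out lower numbers stand for higher toxicity in this test and higher numbers for lower toxicity in this test: compound 3 gives 9.6 ug/mL. Compound 1 `COc1nc(C(C)(C)C)ccc1[C@@H](c1ccccc1)[C@@](O)(CCN(C)C)c1cccc2ccccc12` is reported only as a limit of the assay, and in this assay compound 1 gives > 64 ug/mL. For compound 2 `COc1nc(-c2cccc(Cl)c2)ccc1[C@@H](c1ccccc1)[C@@](O)(CCN(C)C)c1cccc2ccccc12` no result is given, and in this assay compound 2 shows "nd" (no result reported). For the measured compounds named here, the one measured step, an at least 6.6-fold lower number from compound 1 to compound 3 (0.82 log units; beyond the scatter), is large, though it rests on a limit, as the limit of > 64 ug/mL in this assay, at which 1 of the 3 values shown sits, makes clear.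

Compound 4 `COc1nc(-c2ccc(C#N)cc2)ccc1[C@@H](c1ccccc1)[C@@](O)(CCN(C)C)c1cccc2ccccc12` differs from compound 3 by 4-cyanophenyl in place of pyridin-4-yl on an aromatic carbon. Going by the values given here, no measured step exchanges one aryl group for another at this position, so the step from compound 1 to compound 3 bears on it only indirectly: it shows that this position can move the number a long way. Compound 4 is expected to stay close to compound 3, with any shift within or just beyond the scatter, as a 1.2-fold lower number from compound 3 to compound 4 (0.08 log units; within the scatter). Compound 4 is therefore estimated at 8 ug/mL, between 3 ug/mL and 25 ug/mL.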

Compound 4, half-maximal cytotoxic concentration: > 64 ug/mL
Compound 4 gave a limit, no number (the forecaster's own chance of this, stated with the estimate: 15%); middle value at least 8.0-fold (0.90 log units) from the limit.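

Replacing pyridin-4-yl with 4-cyanophenyl gives an at least 6.6-fold higher number from compound 3 to compound 4 (0.82 log units; beyond the scatter) in this assay, so this position separates one aromatic ring from another, not only an aromatic ring from tert-butyl. Carrying an aromatic ring here is therefore not enough for the lower number seen with compound 3, and compound 4 goes against any reading of that kind. Compound 1 and compound 4 both stand as limits, and the step between them cannot be read: the limit of > 64 ug/mL in this assay, at which 2 of the 4 values shown sit.

Compound 2 has no result in this assay, so it does not help to separate these cases. From the compounds shown here alone, it stays open whether an unsubstituted phenyl, a pyridin-3-yl or a 4-aminophenyl group at this place would give a number near that of compound 3 or a limit like that of compound 4.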